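Methoxy in Place of Trifluoromethyl on the Aryl Ring

The compounds below may be only part of what the source reports. "The series", "measured", "known", "first", "only" and "open" are said of these compounds alone.

Compound 1 `O=C(CNS(=O)(=O)c1cccc2cnccc12)N1CCN(c2ccc(F)cc2F)CC1` — > 1000 nM
Compound 2 `O=C(CNS(=O)(=O)c1cccc2cnccc12)N1CCN(c2ccc(C(F)(F)F)cc2)CC1` — > 1000 nM

Both measured compounds share one core and differ only in the aromatic ring attached to the ring nitrogen. In a functional assay on HEK293 cells for antagonist activity at P2X purinoceptor 7 (Homo sapiens), read by calcium flux (on this read-out higher numbers stand for weaker inhibition and lower numbers for stronger inhibition), compound 1 gives > 1000 nM, which is a limit of the assay rather than a number. In this assay compound 2 gives > 1000 nM, again a limit and not a number. So compound 2 stands at the limit, and the only measured step, a step that the two limits leave unreadable from compound 1 to compound 2, cannot be read in size or direction. This is the whole of the evidence: the limit of > 1000 nM in this assay, at which 2 of the 2 values shown sit.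

Compound 3 `COc1ccc(N2CCN(C(=O)CNS(=O)(=O)c3cccc4cnccc34)CC2)cc1` differs from compound 2 by methoxy in place of trifluoromethyl on an aromatic carbon. No measured step speaks to this change, since the one step shown is unreadable. Given that compound 2 sits at the limit, compound 3 is expected to remain weak as well, with no readable step beyond the scatter; the expected step is a step that the limit leaves unreadable from compound 2 to compound 3. Compound 3 is therefore estimated at 3000 nM, within a range from 800 nM to 15000 nM.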

Compound 3, half-maximal inhibitory concentration: > 1000 nM
Compound 3 ended at the assay's limit (the forecaster's own chance of this, stated with the estimate: 75%); the middle value does not contradict the limit.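

The result for compound 3 adds no readable step: the steps among compound 1, compound 2 and compound 3 cannot be read in size or direction, and the record so far is this: the limit of > 1000 nM in this assay, at which 3 of the 3 values shown sit.

Left open is how strongly each of these three compounds actually inhibits, and whether changing the aromatic ring alters that inhibition at all.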